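Cyclopropyl to methyl on the amide nitrogen

The source may hold more compounds than are shown below. What is called first, only, known or untested is meant among the compounds shown, and "the series" means these compounds.

Measured compounds:
compound 1, `CNC(=O)c1cc(C(=O)NC2CC2)cc2c1O[C@H](CF)[C@H]2c1ccccc1`, gives 3.9
compound 2, `CNC(=O)c1cc(C(=O)N[C@H]2[C@@H]3COC[C@@H]32)cc2c1OC[C@H]2c1cccnc1`, gives 1.4

In a physicochemical assay for lipophilicity, at pH 7.4 (a lower number here means a more polar compound, a higher number a more lipophilic compound), compound 1 gives 3.9, the higher of the two numbers; compound 2 gives 1.4, a gap beyond the scatter. Within the data shown here, no pair of measured compounds differs in one place, so no step is known. Compound 3, `CNC(=O)c1cc(C(=O)NC)c2c(c1)[C@H](c1ccccc1)[C@@H](CF)O2`, differs from compound 1 by methyl in place of cyclopropyl on an amide-type nitrogen. A smaller group in the same place is expected to give a moderate fall, a number 0.60 log units lower from compound 1 to compound 3 (beyond the scatter), probably beyond the scatter. Compound 3 is therefore estimated at 3.3, with a range from 2.9 to 3.7.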

Compound 3, distribution coefficient: 3.3
The estimate for compound 3 equals the measured number at the digits printed; the range from low to high includes it.
By their numbers in this assay, from the lowest: compound 2; then compound 3; then compound 1.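

In this assay, the amide-type nitrogen gives the series its first one-place reading: methyl in place of cyclopropyl gives a number 0.60 log units lower from compound 1 to compound 3 (beyond the scatter) with the rest of the structure unchanged. The earlier pair differs in more than one place, so it could assign none of its gap to this group. No measurement available here explains the step.

From the compounds shown here alone, whether a longer chain, such as propyl, or a carboxylic acid on this nitrogen would continue the trend remains open. So does whether the step carries over to the core of compound 2.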